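Amide series: removing the ring methyl from compound 3

A few compounds are considered here, and "the series" means these few. Any claim that something is new, unique, unknown or untested is made for them only; others in the source may bear on it.

Values in an ADME assay on HCT-116 cells (Homo sapiens) for antiproliferative activity; a lower number here means a stronger inhibitor, a higher number a weaker inhibitor:
- Compound 1 `COc1ccc(C(C)=O)cc1COc1ccc(Cl)cc1`: 39000 nM
- Compound 2 `COc1ccc(C(=O)O)cc1COc1ccc(Cl)c(C)c1`: > 50000 nM (a limit)
- Compound 3 `COc1ccc(C(N)=O)cc1COc1ccc(Cl)c(C)c1`: > 50000 nM (a limit)

Compound 3 gives only a limit, with no number behind it. Compound 3 sits at the limit of > 50000 nM in this assay, at which 2 of the 3 values shown sit.

Compound 4 `COc1ccc(C(N)=O)cc1COc1ccc(Cl)cc1` differs from compound 3 as follows: hydrogen in place of methyl on an aromatic carbon. This puts hydrogen in place of methyl on an aromatic carbon, ortho to a chloro group.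

Among the measured compounds shown here, the one measured step, a step that the two limits leave unreadable from compound 2 to compound 3, concerns a carbonyl carbon and not this place. Its size cannot be read, so it offers no size to carry over. For the measured compounds named here, compound 1 also has hydrogen at this place and gives 39000 nM, the only true number so far, though it differs from compound 4 at the carbonyl group. Little movement is therefore expected in this assay, with any change towards stronger inhibition, and another limit is a likely result.

The estimated step is a number no higher from compound 3 to compound 4 (the limit leaves the size open). For compound 4 the expected value is 50000 nM, with an estimated range of 25000 nM to 100000 nM.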

Compound 4, half-maximal inhibitory concentration: > 50000 nM
Compound 4: no number, only a limit; the forecaster's own chance of this, stated with the estimate: 60%; the middle value lies on the limit itself.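

With hydrogen in place of methyl ortho to a chloro group, the amide series still gives no number: in this assay compound 4 gives > 50000 nM, which is a limit. Neither step between limits can be read, so the effect of the methyl at this place stays unmeasured. Among the compounds shown here, the one readable comparison lies at the carbonyl carbon, an at least 1.2-fold higher number from compound 1 to compound 4 (0.10 log units; that floor lies within the scatter), so amino in place of methyl there shows no change beyond the scatter, though the true size may be larger.

On these data alone, whether the methyl matters at all remains open, as most of the values give no size: the limit of > 50000 nM in this assay, at which 3 of the 4 values shown sit. Also open is whether an amine in place of the carbonyl group, or a longer chain on the carbonyl carbon, would bring a true number in this assay.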